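The compounds below may be only part of what the source reports. "The series", "measured", "known", "first", "only" and "open" are said of these compounds alone.

Measured compounds and values:
Compound 1, `C=C1C[C@]23C[C@@]1(O)CC[C@H]2c1ccc(OS(=O)(=O)c2ccc(C)cc2)c(C)c1[C@@H]3Cn1cc(-c2ccc(Br)cc2)nn1`, in a functional assay on HL-60 cells (Homo sapiens) for cytotoxicity, read by MTT assay, with a stated time of 4 days (on this read-out lower numbers stand for stronger inhibition and higher numbers for weaker inhibition), gives > 20000 nM.
Compound 2, `C=C1C[C@]23C[C@@]1(O)CC[C@@H]2c1cccc(C)c1[C@@H]3Cn1cc(-c2ccc(Br)cc2)nn1`, in this assay gives > 20000 nM.
Compound 3, `C=C1C(=O)[C@]23C[C@@]1(O)CC[C@H]2c1ccc(O)c(C)c1[C@@H]3Cn1cc(-c2ccc(C(F)(F)F)cc2)nn1`, in this assay gives 720 nM.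

The value of compound 1 is a limit of the assay, not a measured number. The value of compound 2 is likewise only a limit. Compound 2 therefore stands at the limit of > 20000 nM in this assay, at which 2 of the 3 values shown sit, with no measurable inhibition to report. Among the compounds with values here, the only numbered result belongs to compound 3, whose core differs from that of compound 2 in more than one place, so no single step between them can be read from the numbers.

Compound 4, `C=C1C[C@]23C[C@@]1(O)CC[C@@H]2c1cccc(C)c1[C@@H]3Cn1cc(-c2ccccn2)nn1`, differs from compound 2 in one place: pyridin-2-yl in place of 4-bromophenyl on an aromatic carbon. No measured pair among the compounds shown carries this change, so there is no step to lean on. With compound 2 giving only a limit, compound 4 is expected to give no step beyond the scatter, a step that the limit leaves unreadable from compound 2 to compound 4, and most likely to return a limit as well. Compound 4 is estimated at 25000 nM, with a range from 6000 nM to 100000 nM.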

Compound 4, half-maximal inhibitory concentration: > 20000 nM
Compound 4 ended at the assay's limit; the forecaster's own chance of this, stated with the estimate: 70%; the middle value is on the limit's open side.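

No step can be read from compound 2 to compound 4, since each gives only a limit, not a number: the limit of > 20000 nM in this assay, at which 3 of the 4 values shown sit. Still open, from the compounds shown here alone, is which of the several places separating compound 2 from compound 3, at 720 nM, matters for cytotoxicity.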